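Sultam to lactam swap on a benzamide series

This account rests on a few compounds, and the source may have more. Where it says the series, first, only, none or still open, it means among the compounds named here.

The compounds share a core in which a benzyl group carries an amide on one side and a bicyclic ring on the other. In an ADME assay on RAW264.7 cells (Mus musculus) for cytotoxicity, read by WST assay (a lower number here means that less compound is tolerated, a higher number that more compound is tolerated), compound 1 `O=C(c1ccc(CN2Cc3ccccc3S2(=O)=O)cc1)N1CCCCC1` reaches only the limit of > 100000 nM. Compound 3 `O=C(NCc1ccco1)c1ccc(CN2Cc3ccccc3S2(=O)=O)cc1` likewise gives a limit of > 100000 nM in this assay. Compound 2 `CC(C)(C)OC(=O)N(Cc1ccco1)C(=O)c1ccc(CN2Cc3ccccc3S2(=O)=O)cc1` stands at the same limit of > 100000 nM in this assay, so no number is known for it, only a boundary. The two measured steps, a step that the two limits leave unreadable from compound 1 to compound 3 and a step that the two limits leave unreadable from compound 2 to compound 3, therefore cannot be read, a situation summarised by the limit of > 100000 nM in this assay, at which 3 of the 3 values shown sit.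

Compound 4 `CC(C)(C)OC(=O)N(Cc1ccco1)C(=O)c1ccc(CN2Cc3ccccc3C2=O)cc1` differs from compound 2 by a group of 10 heavy atoms (8 carbon, 1 nitrogen, 1 oxygen; one five-membered non-aromatic ring with 1 hetero atom, one six-membered aromatic ring of carbon only) in place of a group of 11 heavy atoms (7 carbon, 1 nitrogen, 2 oxygen, 1 sulfur; one five-membered non-aromatic ring with 2 hetero atoms, one six-membered aromatic ring of carbon only), on a saturated chain carbon bound to an aromatic carbon. Among the compounds with values here, no measured step touches this part of the molecule, so the expectation rests only on the three limits already seen. The step from compound 2 to compound 4 is thus estimated as a step that the limit leaves unreadable from compound 2 to compound 4, with no direction beyond the scatter. Compound 4 is expected to give about 150000 nM in this assay, within a range from 60000 nM to 400000 nM.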

Compound 4, concentration lethal to 50% of the cells: 95200 nM
Compound 4: middle estimate off by 1.6-fold (0.20 log units), on the high side, within the range that was stated.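

Within the data shown here, compound 4 is the first compound to give a number rather than a limit in this assay, at 95200 nM. The change on the saturated chain carbon bound to an aromatic carbon amounts to an at least 1.0-fold lower number from compound 2 to compound 4 (0.02 log units; that floor lies within the scatter), so it shows no shift that can be told from the scatter, although the true step may be larger. Compound 2 gives only a limit, and its distance from compound 4 cannot be fixed while most of the series stays there: the limit of > 100000 nM in this assay, at which 3 of the 4 values shown sit.

The compounds shown leave open whether the same change would give a readable number on compound 1 or compound 3. They also leave open how an amine or a carboxylic acid at this place would read in this assay.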